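Compound 4 and the Z double bond

The source may hold more compounds than are shown below. What is called first, only, known or untested is meant among the compounds shown, and "the series" means these compounds.

Compounds measured so far:
Compound 1 `Fc1ccc(/C=C\c2cc3ccccc3nc2Cl)cc1` gives 5290 nM
Compound 2 `Fc1ccc(/C=C/c2cc3ccccc3nc2Cl)cc1` gives 120 nM
Compound 3 `Fc1ccc(/C=C\c2cc3ccc(Cl)cc3nc2Cl)cc1` gives 10900 nM

In a functional assay on MDA-MB-468 cells (Homo sapiens) for antiproliferative activity, read by sulforhodamine B assay, with a stated time of 72 h (a lower number here means a stronger inhibitor, a higher number a weaker inhibitor), compound 1 stands second highest of the three numbers, with compound 3 its nearest neighbour and compound 2 the furthest away. The compound still to be measured is compound 4 `COc1ccc2nc(Cl)c(/C=C\c3ccc(F)cc3)cc2c1`, which keeps the double bond drawn Z as in compound 1. The structural change is methoxy in place of hydrogen on an aromatic carbon, which in words is methoxy in place of hydrogen on an aromatic carbon.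

For the measured compounds named here, two measured steps bear on this change, though not equally. The large 44-fold lower number from compound 1 to compound 2 (1.64 log units; beyond the scatter) goes with the fact that compounds 1 and 2 differ only in the configuration as drawn. Compound 4 keeps the Z drawing, so that step offers no direct guide. The closer guide is a 2.1-fold higher number from compound 1 to compound 3 (0.31 log units; beyond the scatter), a modest step for chloro in place of hydrogen on an aromatic carbon. This is a single example with a different group, so only a small step is expected in this assay, leaning towards a higher number and quite possibly staying within the scatter.

The expected change is a 1.1-fold higher number from compound 1 to compound 4 (0.05 log units; within the scatter).

For compound 4 the estimated value is 6000 nM, with an expected range from 2000 nM to 18000 nM.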

Compound 4, half-maximal inhibitory concentration: 15200 nM
Estimate against measurement, compound 4: 2.5-fold (0.40 log units) below; low and high end bracket the measured number.
By their numbers in this assay, from the lowest: compound 2; then compound 1; then compounds 3 and 4 (each within the scatter of the next).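

In this assay, the methoxy replacement gives a 2.9-fold higher number from compound 1 to compound 4 (0.46 log units; beyond the scatter), so hydrogen at this aromatic carbon, meta to a fused ring and para to a fused ring, cannot be exchanged for methoxy without a measurable loss on the Z-drawn compound. Together with a 2.1-fold higher number from compound 1 to compound 3 (0.31 log units; beyond the scatter), this makes two different replacements of hydrogen on an aromatic carbon of compound 1 that both move the number upward beyond the scatter, and neither of the compounds shown with such a replacement goes against that direction, although two examples are a thin basis for any pattern. The one available fact concerns only the configuration of the double bond, which compound 4 shares with compound 1, so no measured finding here accounts for the methoxy step.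

The compounds shown leave open whether the same replacement would raise the number on the E-drawn compound 2, which is the form with the lowest number here. They also leave open how a hydroxyl group, an amine or a longer chain such as ethoxy would behave on this same carbon.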